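This account rests on a few compounds, and the source may have more. Where it says the series, first, only, none or still open, it means among the compounds named here.

In a functional assay on A20 cells (Mus musculus) for inhibition, with stated times of 1 h, 16 h and 24 h (a lower number here means a stronger inhibitor, a higher number a weaker inhibitor), three related compounds have been measured. Compound 1 (`N#CCNC(=O)[C@@H]1C[C@@H](S(=O)(=O)c2ccccc2Cl)C[C@H]1C(=O)N1CCOCC1`) gives 3 nM, compound 2 (`CC(C)(C#N)NC(=O)[C@@H]1C[C@@H](S(=O)(=O)c2ccccc2)C[C@H]1C(=O)N1CCOCC1`) gives 43 nM, and compound 3 (`N#CC1(NC(=O)[C@@H]2C[C@@H](S(=O)(=O)c3ccccc3)C[C@H]2C(=O)N2CCCCC2)CC1`) gives 5 nM. The values of compound 3 and compound 1 lie within the usual scatter of each other, so this assay does not separate them. Compound 3 is clearly the stronger inhibitor when set against compound 2, as that gap lies beyond the scatter.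

The next compound to be tested is compound 4 (`N#CC1(NC(=O)[C@@H]2C[C@@H](S(=O)(=O)c3ccccc3)C[C@H]2C(=O)N2CCC2)CC1`). It keeps everything in compound 3 except for one ring, with azetidin-1-yl in place of piperidin-1-yl on a carbonyl carbon. Among the measured compounds shown here, the measured compounds differ from one another in more than one place, so no measured pair shows the effect of this change on its own. Any forecast therefore starts from compound 3 at 5 nM and has to allow wide margins.

A modest loss of inhibition seems the likeliest outcome, meaning a somewhat higher number that may not clear the scatter. The estimate means an expected step of a 1.6-fold higher number from compound 3 to compound 4 (0.20 log units; within the scatter). For compound 4 the expected value is 8 nM, with an estimated range from 3 nM to 25 nM.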

Compound 4, half-maximal inhibitory concentration: 44 nM
Beside the measured number, compound 4's estimate is 5.5-fold (0.74 log units) below it; the whole stated range lies below it.
By their numbers in this assay, from the lowest: compounds 1 and 3 (each within the scatter of the next); then compounds 2 and 4 (each within the scatter of the next).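

Among the compounds shown here, compound 3 and compound 4 form the first pair in this set that differs in only one place, so the effect of a single change can now be read on its own: in this assay, azetidin-1-yl in place of piperidin-1-yl on a carbonyl carbon gives an 8.8-fold higher number from compound 3 to compound 4 (0.94 log units; beyond the scatter). This shows that the ring on this carbonyl carbon is not a neutral part of the structure, since inhibition in this assay responds to the swap even though both groups count 0 hydrogen-bond donors, 0 hydrogen-bond acceptors and no net charge. The measurements available give no explanation for the size of this step.

Going by these compounds, a single pair gives only two points, so it remains open how inhibition changes across other groups at this carbonyl carbon, such as the five-membered pyrrolidin-1-yl ring or the open-chain diethylamino group. On these data alone, it also remains open whether the same swap would have a similar effect when the other parts of the molecule differ, for example with another group on the sulfonyl-bearing phenyl ring.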